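The source may report more compounds than this note shows. Statements on the series, on what has been measured and on what is new or still open speak of the compounds shown alone.

Compound 1 `CCc1ccc2nc(C(=O)Nc3c(F)cc(-c4cccc(F)c4)cc3F)c(C)c(O)c2c1` gives -0.35% in a functional assay on A-375 cells (Homo sapiens) for antiproliferative activity, read by MTT assay, with a stated time of 24 h, tested at 0.01 ug/mL; a higher number here means a stronger effect of the compound at the concentration tested, a lower number a weaker effect.
Compound 2 `CCOc1ccc2nc(C(=O)Nc3c(F)cc(-c4cccc(F)c4)cc3F)c(C)c(O)c2c1` gives 0.23% in this assay.

Both measured compounds share one core and differ only in a single group on it. On the numbers shown, compound 2 and compound 1 cannot be told apart: the step from one to the other, a number 0.6 percentage points higher from compound 1 to compound 2 (within the scatter), lies within the scatter, and both read-outs sit close to zero, meaning that at this concentration neither compound measurably slows the growth of the cells.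

Compound 3 `Cc1c(C(=O)Nc2c(F)cc(-c3cccc(F)c3)cc2F)nc2ccc(OC(F)(F)F)cc2c1O` is not yet measured. It differs from compound 2 by trifluoromethyl in place of ethyl on an oxygen on an aromatic ring. This alters the same part of the molecule that was altered between compound 1 and compound 2, and that earlier exchange produced no step beyond the scatter. Nothing in the two measured values points to a move away from zero, so the expected step from compound 2 to compound 3 is a number 0.3 percentage points higher from compound 2 to compound 3 (within the scatter), none beyond the scatter. The estimate for compound 3 in this assay is therefore 0.5%, with a range from -8% to 10%.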

Compound 3, a percentage reported as inhibition, at one concentration (the size of the read-out at that concentration, not a potency): -0.68%
Compound 3: the middle estimate sits 1.2 percentage points above what was measured; measured number inside the range.
By their numbers in this assay, from the lowest: compounds 3, 1 and 2 (each within the scatter of the next).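

Swapping the ethyl on the oxygen for trifluoromethyl, which turns ethoxy into trifluoromethoxy, gives in this assay a step of a number 0.9 percentage points lower from compound 2 to compound 3 (within the scatter) and so does not separate the two compounds. Compared with the ethyl group of compound 1, trifluoromethoxy on the same aromatic carbon gives a number 0.3 percentage points lower from compound 1 to compound 3 (within the scatter) and does not separate those two either. Among the compounds shown here, with three different groups now tested at this one place, including the first fluorinated group there, all three read-outs remain close to zero, which extends the flat picture beyond the single exchange seen earlier. No measurement shown here offers an explanation for this flat result. Still open, going by these compounds, is whether an amine, a carboxylic acid or a longer chain such as butoxy at this place would move the read-out away from zero. Since every compound shown sits near zero at a single concentration, these numbers also cannot tell whether the choice of group here would matter at a concentration where the cells respond.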